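Methyl in place of trifluoromethyl, measured once and expected once

The source may report more compounds than this note shows. Statements on the series, on what has been measured and on what is new or still open speak of the compounds shown alone.

Compound 1, `NC(=O)c1c(NC(=O)c2ccc(C(F)(F)F)cc2)sc2c1CCN(Cc1ccc(Cl)cc1Cl)C2`, gives only a limit in a functional assay on HeLa cells (Homo sapiens) for antiproliferative activity, with a stated time of 24 h; on this read-out lower numbers stand for stronger inhibition and higher numbers for weaker inhibition: > 50000 nM.
Compound 2, `Cc1ccc(C(=O)Nc2sc3c(c2C(N)=O)CCN(Cc2ccc(Cl)cc2Cl)C3)cc1`, likewise gives only a limit in this assay: > 50000 nM.
Compound 3, `NC(=O)c1c(NC(=O)c2ccccc2Cl)sc2c1CCN(C(=S)Nc1ccccc1C(F)(F)F)C2`, gives in this assay 26700 nM.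

The change from compound 1 to compound 2 is methyl in place of trifluoromethyl on an aromatic carbon. Its size is a step that the two limits leave unreadable from compound 1 to compound 2, since both values sit at the limit of > 50000 nM in this assay, at which 2 of the 3 values shown sit. Compound 3 carries the same change toward compound 4, `Cc1ccccc1NC(=S)N1CCc2c(sc(NC(=O)c3ccccc3Cl)c2C(N)=O)C1`, namely (methyl in place of trifluoromethyl on an aromatic carbon). The two places are not identical: in the measured pair the methyl stands para to a large group, in the new pair ortho to a large group, so this is the same kind of change rather than the same one. How the core of compound 3 differs from the core of compound 1 is not broken down here.

The step from compound 3 to compound 4 in this assay is expected to be a 1.1-fold higher number from compound 3 to compound 4 (0.05 log units; within the scatter), resting on the fact that the measured pair gives no readable step and on the value of compound 3, 26700 nM. Compound 4 is estimated at 30000 nM, between 8000 nM and 100000 nM.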

Compound 4, half-maximal inhibitory concentration: > 50000 nM
Compound 4: only a limit was reported (the forecaster's own chance of this, stated with the estimate: 45%); at least 1.6-fold (0.22 log units) between middle value and limit.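

In this assay, methyl in place of trifluoromethyl on the core of compound 3 reads as an at least 1.8-fold higher number from compound 3 to compound 4 (0.27 log units; that floor lies within the scatter), and this is a floor on the step and not its size, so it does not establish a real difference between the two compounds. Compound 4 gives > 50000 nM, which is a limit of the assay and not a number. The same change on the core of compound 1 cannot be read, so the two cores cannot be compared and the data neither show that the change carries from one core to the other nor show that it fails to: the limit of > 50000 nM in this assay, at which 3 of the 4 values shown sit.

From the compounds shown here alone, it remains open how far the number would move if an amine or a carboxylic acid stood in place of trifluoromethyl, on the same aromatic carbon ortho to a large group. Also open, going by these compounds, is whether trifluoromethyl makes any difference on the core of compound 1, where neither compound of the pair gives a number.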